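Bromo in place of methyl: expectation for compound 3

The source may report more compounds than this note shows. Statements on the series, on what has been measured and on what is new or still open speak of the compounds shown alone.

In a functional assay on KG-1 cells (Homo sapiens) for cytotoxicity, read by luminescence and CellTiter-Glo, with a stated time of 3 days (a lower number here means a stronger inhibitor, a higher number a weaker inhibitor), compound 2 (`Cc1ccc(O)c(C(=O)Nc2ccc(C#N)cc2)c1`) gives 3370 nM and compound 1 (`N#Cc1ccc(NC(=O)c2cc(Cl)ccc2O)cc1`) gives 1860 nM. Going by the values given here, these are the only two numbers so far, and they lie within the scatter of each other.

Compound 3 (`N#Cc1ccc(NC(=O)c2cc(Br)ccc2O)cc1`) has bromo in place of methyl on an aromatic carbon, para to a hydroxy group: bromo in place of methyl on an aromatic carbon. Among the compounds with values here, the one measured step that bears on this change is a 1.8-fold higher number from compound 1 to compound 2 (0.26 log units; within the scatter), with methyl in place of chloro on an aromatic carbon. Within the data shown here, that step stays within the scatter, and no measured step yet involves bromo, so no shift beyond the scatter is expected in this assay. The expected step is a 1.5-fold lower number from compound 2 to compound 3 (0.19 log units; within the scatter), which would remain within the scatter. For compound 3 the estimated value is 2200 nM, with an expected range of 1000 nM to 4800 nM.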

Compound 3, half-maximal inhibitory concentration: 1290 nM
For compound 3 the middle estimate is 1.7-fold (0.23 log units) above the measured one, within the range that was stated.
By their numbers in this assay, from the lowest: compounds 3, 1 and 2 (each within the scatter of the next, the first and the last beyond it).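

In this assay, the position para to a hydroxy group now yields its first step beyond the scatter, with bromo in place of methyl giving (a modest change) a 2.6-fold lower number from compound 2 to compound 3 (0.42 log units; beyond the scatter), whereas the earlier methyl and chloro pair stayed within it. Bromo in place of chloro gives a 1.4-fold lower number from compound 1 to compound 3 (0.16 log units; within the scatter), so this position does not separate these two halogens, and methyl is separated only from bromo. The data on hand offer no measurement that explains the methyl to bromo step.

Going by these compounds, whether fluoro, methoxy, an amine or a carboxylic acid at this position would fall with bromo and chloro or with methyl remains open. Also open, on these data alone, is whether the step from methyl to bromo would persist with the nitrile replaced by another group, such as an amide.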